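Cyclopropyloxy azetidine analogue of compound 2

A few compounds are considered here, and "the series" means these few. Any claim that something is new, unique, unknown or untested is made for them only; others in the source may bear on it.

Measured compounds:
compound 1 `CSc1cc(C)[nH]c(=O)c1CNC(=O)c1c(C)n([C@H](C)[C@H]2CC[C@H](NC3COC3)CC2)c2ccccc12` — in an assay on Sf9 cells for inhibition of histone-lysine N-methyltransferase EZH2 (Homo sapiens), read by scintillation counting, with stated times of 5 h and 20 h (a higher number here means a weaker inhibitor, a lower number a stronger inhibitor), compound 1 gives 0.13 nM
compound 2 `CSc1cc(C)[nH]c(=O)c1CNC(=O)c1c(C)n([C@H](C)[C@H]2CC[C@H](N3CC(OC(F)F)C3)CC2)c2ccccc12` — in this assay compound 2 gives 0.1 nM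

For the measured compounds named here, compound 2 sits within the scatter of compound 1, the only other measured compound; the gap a 1.3-fold lower number from compound 1 to compound 2 (0.11 log units; within the scatter) is the sole recorded step and concerns the whole amine on the saturated ring. Compound 3 `CSc1cc(C)[nH]c(=O)c1CNC(=O)c1c(C)n([C@H](C)[C@H]2CC[C@H](N3CC(OC4CC4)C3)CC2)c2ccccc12` differs from compound 2 by cyclopropyl in place of difluoromethyl on an oxygen on a saturated carbon. Going by the values given here, no measured step touches the substituent on the azetidine oxygen, so nothing points to a shift beyond the scatter. Compound 3 is therefore expected to give 0.12 nM (range 0.05 nM to 0.3 nM), an estimated step of a 1.2-fold higher number from compound 2 to compound 3 (0.08 log units; within the scatter).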

Compound 3, half-maximal inhibitory concentration: 0.072 nM
Estimate against measurement, compound 3: 1.7-fold (0.22 log units) above, and the stated range covers the measured number.
By their numbers in this assay, from the lowest: compounds 3, 2 and 1 (each within the scatter of the next).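

In this assay, cyclopropyl in place of difluoromethyl on an oxygen on a saturated carbon leaves the number within the scatter (a 1.4-fold lower number from compound 2 to compound 3 (0.14 log units; within the scatter)), so this position holds a fluorine-free group of the same heavy-atom count without a step beyond the scatter. The wider exchange of 3-(cyclopropyloxy)azetidin-1-yl for (oxetan-3-yl)amino also stays within the scatter (a 1.8-fold lower number from compound 1 to compound 3 (0.26 log units; within the scatter)). No evidence on hand bears on these steps.

Going by these compounds, whether a free hydroxyl, a phenyl ring or a longer chain on that oxygen would move the number beyond the scatter remains open.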